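Chloro in Place of Methyl: From Compound 1 to Compound 3

A few compounds are considered here, and "the series" means these few. Any claim that something is new, unique, unknown or untested is made for them only; others in the source may bear on it.

Going by the values given here, compound 1 `Cc1ccc(-c2ncnc3c2ncn3C[C@@H]2C[C@H](CO)c3ccccc32)cc1` is the stronger of the two compounds measured so far in a functional assay on MOLT-4 cells (Homo sapiens) (a higher number here means a weaker inhibitor, a lower number a stronger inhibitor), where compound 1 gives 1.4 ug/mL. Compound 2 `Cn1ncc2c1[C@@H](CO[Si](c1ccccc1)(c1ccccc1)C(C)(C)C)C[C@H]2Cn1cnc2c(O)ncnc21`, built differently, gives 3.2 ug/mL in this assay, a number that lies beyond the usual scatter above that of compound 1. Compound 3 `OC[C@H]1C[C@@H](Cn2cnc3c(-c4ccc(Cl)cc4)ncnc32)c2ccccc21` differs from compound 1 in one place: chloro in place of methyl on an aromatic carbon. Among the compounds with values here, no measured pair shows this exchange, so its effect in this assay cannot be read from the data at hand. With one heavy atom swapped for another and no change in donors or acceptors, the step is expected to be small, in no clear direction and within the scatter; the estimated step is no change at the digits printed from compound 1 to compound 3 (within the scatter). Compound 3 is therefore expected to give about 1.4 ug/mL in this assay, within a likely range from 0.6 ug/mL to 3.5 ug/mL.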

Compound 3, half-maximal inhibitory concentration: 0.63 ug/mL
Beside the measured number, compound 3's estimate is 2.2-fold (0.35 log units) above it, and the stated range covers the measured number.
By their numbers in this assay, from the lowest: compound 3; then compound 1; then compound 2.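

In this assay the exchange of 4-methylphenyl to 4-chlorophenyl gives a 2.2-fold lower number from compound 1 to compound 3 (0.35 log units; beyond the scatter) and so shows that this site, para to a large group, responds to the swap of a single heavy atom, even though the count of hydrogen-bond donors and acceptors and the net charge stay the same. Going by these compounds alone, the two earlier compounds differ in more than one place, so this is the first step in the set that can be tied to one position. Nothing in the data at hand accounts for the step.

The compounds shown leave open how a bromo, a methoxy, an amine or a carboxylic acid at this position would compare with chloro and methyl. They also leave open whether the same exchange would give a similar step on the core of compound 2.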